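Expected Cytotoxicity After a Sulfonamide Substituent Exchange

The compounds below may be only part of what the source reports. "The series", "measured", "known", "first", "only" and "open" are said of these compounds alone.

Three measured compounds share one core and differ in the group on the sulfonamide nitrogen. In a functional assay on B16-F10 cells (Mus musculus) for cytotoxicity, read by CCK-8 assay, with a stated time of 48 h (a lower number here means a stronger inhibitor, a higher number a weaker inhibitor), compound 1 `Cc1cc(NS(=O)(=O)c2ccc(/N=C/c3c(Cl)c4ccccc4oc3=O)cc2)no1` gives 270 nM. In this assay compound 2 `Cc1ccc2oc(=O)c(/C=N/c3ccc(S(=O)(=O)Nc4nccs4)cc3)c(Cl)c2c1` gives 280 nM, and compound 3 `Cc1ccc2oc(=O)c(/C=N/c3ccc(S(=O)(=O)NC(=N)N)cc3)c(Cl)c2c1` gives 240 nM. Compound 3 stands lowest of the three numbers, yet both other values lie within the scatter of it, so no order can be read from them. Going by the values given here, the one step between neighbours, a 1.2-fold lower number from compound 2 to compound 3 (0.07 log units; within the scatter), is also within the scatter.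

Compound 4 `Cc1ccc2oc(=O)c(/C=N/c3ccc(S(=O)(=O)Nc4cc(C)on4)cc3)c(Cl)c2c1` is reached from compound 3 by a group of 6 heavy atoms (4 carbon, 1 nitrogen, 1 oxygen; one five-membered aromatic ring with 2 hetero atoms) in place of a group of 3 heavy atoms (1 carbon, 2 nitrogen; no ring), on a sulfonamide nitrogen. Among the compounds with values here, the step from compound 2 to compound 3 is the only measured change at this nitrogen, and it was a 1.2-fold lower number from compound 2 to compound 3 (0.07 log units; within the scatter). Compound 1 carries the same 5-methyl-1,2-oxazol-3-yl group on a different core and gives 270 nM, close to compound 3. The step from compound 3 to compound 4 is therefore expected to be a 1.1-fold higher number from compound 3 to compound 4 (0.03 log units; within the scatter), nothing beyond the scatter. Compound 4 is estimated at 260 nM, with a range from 140 nM to 480 nM.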

Compound 4, half-maximal inhibitory concentration: 250 nM
The estimate for compound 4 lay 1.0-fold (0.02 log units) above the measured number, within the range that was stated.
By their numbers in this assay, from the lowest: compounds 3, 4, 1 and 2 (each within the scatter of the next).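

In this assay the 5-methyl-1,2-oxazol-3-yl group on the sulfonamide nitrogen changes little relative to the group it replaces (a 1.0-fold higher number from compound 3 to compound 4 (0.02 log units; within the scatter)), although the exchange brings in a five-membered aromatic ring and removes both hydrogen-bond donors. The exchange of 1,3-thiazol-2-yl for 5-methyl-1,2-oxazol-3-yl likewise stays within the scatter (a 1.1-fold lower number from compound 2 to compound 4 (0.05 log units; within the scatter)), so all three groups at this nitrogen on the shared core now read alike. Going by these compounds alone, compound 4 also gives the first look at a change away from this nitrogen, methyl in place of hydrogen on an aromatic carbon, and that too makes no readable difference (a 1.1-fold lower number from compound 1 to compound 4 (0.03 log units; within the scatter)).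

No other measurement bears on these values. As far as these compounds go, how a small alkyl group such as methyl, or a carboxylic acid, on the sulfonamide nitrogen would read remains open.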